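The source may hold more compounds than are shown below. What is called first, only, known or untested is meant among the compounds shown, and "the series" means these compounds.

Of the compounds shown here, two of a shared core have so far been measured in a physicochemical assay for lipophilicity, at pH 7.4; on this read-out higher numbers stand for higher lipophilicity and lower numbers for lower lipophilicity. Compound 1 `CNC(=O)c1cc(C(=O)NC2CC2)cn(Cc2cccc(F)c2)c1=O` gives 3.2 in this assay, and compound 2 `CNC(=O)c1cc(C(N)=O)cn(Cc2ccccc2)c1=O` gives 2. Of these two numbers, compound 1 stands highest, and the gap between compound 1 and compound 2 lies beyond the usual scatter of the measurement. The two differ in more than one place, so nothing can be said about how any single part of that gap arises.

Compound 3 `CNC(=O)c1cc(C(=O)NC2CC2)cn(Cc2ccccc2F)c1=O` has not yet been measured in this assay. It differs from compound 1 by 2-fluorophenyl in place of 3-fluorophenyl on a saturated chain carbon bound to an aromatic nitrogen; the two have the same atoms, joined differently, with 2-fluorophenyl in place of 3-fluorophenyl on a saturated chain carbon bound to an aromatic nitrogen. For the measured compounds named here, no measured pair in this set isolates a change of that kind, so the expectation rests on the shift being a small one. The step from compound 1 to compound 3 in this assay is expected to be a number 0.10 log units lower from compound 1 to compound 3 (within the scatter), which would not exceed the scatter. Compound 3 is therefore estimated at 3.1 in this assay, with a range from 2.7 to 3.5.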

Compound 3, distribution coefficient: 3
Estimate against measurement, compound 3: 0.10 log units above; the measured number falls inside the stated range.
By their numbers in this assay, from the lowest: compound 2; then compounds 3 and 1 (each within the scatter of the next).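

In this assay, 2-fluorophenyl in place of 3-fluorophenyl on a saturated chain carbon bound to an aromatic nitrogen gives a number 0.20 log units lower from compound 1 to compound 3 (within the scatter), so on this read-out compound 1 and compound 3 cannot be told apart. For the compounds shown here, this is the first step in the set confined to one place, since the only earlier pair differed in more than one, and it shows that exchanging 3-fluorobenzyl for 2-fluorobenzyl at this position leaves the number within the usual scatter of the measurement. Nothing measured here bears on why the step is this size.

The compounds shown leave open whether a different group on the phenyl ring at this position, such as a methoxy group, a chlorine atom or an amine, or a longer chain in place of the single saturated chain carbon, would produce a step beyond the scatter. They also leave open whether 2-fluorophenyl in place of 3-fluorophenyl would give a step of similar size if a carboxylic acid stood elsewhere on the shared core.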